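Trading a Ketone for an Alkene on the Shared Core

The compounds below may be only part of what the source reports. "The series", "measured", "known", "first", "only" and "open" are said of these compounds alone.

Compound 1 `CCC(=O)c1c(C)nn(CCCN2CCN(c3ccc(C)cc3)CC2)c(=O)c1N`: 40%
Compound 2 `CCCCC(=O)c1c(C)nn(CCCN2CCN(c3ccc(C)cc3)CC2)c(=O)c1N`: 23%
Compound 3 `C=Cc1c(CCC)nn(CCCN2CCN(c3ccc(C)cc3)CC2)c(=O)c1N`: 7%

In a functional assay on the whole organism (Abdomen, strain Swiss) for inhibition, with Mus musculus as the target, with stated times of 30 min, 10 min and 5 min, at a dose of 20 mg/kg by the oral route (a higher number here means a stronger effect of the compound at the dose given, a lower number a weaker effect), compound 2 gives the second highest of these three numbers: compound 1 stands above it beyond the scatter, and compound 3 stands below it beyond the scatter. Compound 4 `CC/C=C/c1c(C)nn(CCCN2CCN(c3ccc(C)cc3)CC2)c(=O)c1N` differs from compound 2 in one place: but-1-en-1-yl in place of butylcarbonyl on an aromatic carbon. Among the measured compounds shown here, the only measured step, a number 17 percentage points lower from compound 1 to compound 2 (beyond the scatter), altered the chain and kept the carbonyl, so it does not speak directly to this change. Compound 3 also carries a double bond outside aromatic rings where compounds 1 and 2 carry a carbonyl, but it differs from them in a second place as well, so its value is only a hint. The step is expected to be a number 11 percentage points lower from compound 2 to compound 4 (beyond the scatter). Compound 4 is estimated at 12%, between 0% and 30%.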

Compound 4, a percentage reported as inhibition, in the whole organism at one dose (the size of the read-out at that dose, not a potency): 35%
For compound 4 the middle estimate is 23 percentage points below the measured one, outside the stated range (above it).
By their numbers in this assay, from the lowest: compound 3; then compound 2; then compounds 4 and 1 (each within the scatter of the next).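

In this assay the carbonyl on this aromatic carbon proves not to be needed for the effect at this dose. Putting but-1-en-1-yl in place of butylcarbonyl gives a number 12 percentage points higher from compound 2 to compound 4 (beyond the scatter) and so recovers part of what the longer ketone chain had lost, while putting it in place of propanoyl gives a number 5 percentage points lower from compound 1 to compound 4 (within the scatter) here. Nothing measured on these compounds explains this result. On these data alone, it remains open whether the double bond itself matters, since a saturated butyl chain would test that, and whether an amine at this position would keep the effect.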